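A Methoxy Group Added to Compound 2

The source may hold more compounds than are shown below. What is called first, only, known or untested is meant among the compounds shown, and "the series" means these compounds.

Of the compounds shown here, three sharing one core have been tested in a functional assay on BGC-823 cells (Homo sapiens) for cytotoxicity, read by MTT assay; on this read-out higher numbers stand for weaker inhibition and lower numbers for stronger inhibition. Compound 1 `Cc1nc(Nc2cccc(Cl)c2)sc1C(=O)/C=C/c1ccccc1` gives only a limit in this assay, > 25000 nM. Compound 2 `Cc1nc(Nc2ccc(Cl)c(Cl)c2)sc1C(=O)/C=C/c1ccccc1` gives 10600 nM, and compound 3 `Cc1nc(Nc2ccccc2)sc1C(=O)/C=C/c1ccccc1` gives 19500 nM. Of the two numbers that are not limits, compound 2 holds the lower one, but the step of a 1.8-fold higher number from compound 2 to compound 3 (0.26 log units; within the scatter) lies within the scatter, so the two cannot be set apart. The step of an at least 2.3-fold lower number from compound 1 to compound 2 (0.37 log units; beyond the scatter) is beyond the scatter, while an at least 1.2-fold lower number from compound 1 to compound 3 (0.10 log units; that floor lies within the scatter) has a floor that lies within it, and the value of compound 1 is a limit (the limit of > 25000 nM in this assay, at which 1 of the 3 values shown sits).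

Compound 4 `COc1cccc(/C=C/C(=O)c2sc(Nc3ccc(Cl)c(Cl)c3)nc2C)c1` differs from compound 2 by methoxy in place of hydrogen on an aromatic carbon. Among the measured compounds shown here, every measured step alters the group on the nitrogen, whereas this change falls on the phenyl that becomes 3-methoxyphenyl, so none of the measured steps bears on it directly. For compound 4 the expected step is therefore none beyond the scatter, a 1.1-fold lower number from compound 2 to compound 4 (0.03 log units; within the scatter). The estimate for compound 4 in this assay is 10000 nM, between 4000 nM and 25000 nM.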

Compound 4, half-maximal inhibitory concentration: 8350 nM
Estimate against measurement, compound 4: 1.2-fold (0.08 log units) above; measured number inside the range.
By their numbers in this assay, from the lowest: compounds 4, 2 and 3 (each within the scatter of the next, the first and the last beyond it). At a limit, above all of these: compound 1.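

In this assay, the change from phenyl to 3-methoxyphenyl gives a 1.3-fold lower number from compound 2 to compound 4 (0.10 log units; within the scatter), so compound 2 and compound 4 cannot be set apart. Among the compounds shown here, every earlier step altered the group on the nitrogen, which makes this the first reading of the phenyl that becomes 3-methoxyphenyl: at this aromatic carbon, methoxy in place of hydrogen brings no shift beyond the scatter. Nothing shown here gives a reason for this result.

On these data alone, whether an amine, a carboxylic acid or a longer alkoxy chain on this same aromatic carbon would stay within the scatter of compound 2 remains open. Also open, as far as these compounds go, is whether methoxy on the other carbons of this ring, or with the plain phenyl on the nitrogen of compound 3, would read the same way.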